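A few compounds are considered here, and "the series" means these few. Any claim that something is new, unique, unknown or untested is made for them only; others in the source may bear on it.

In a physicochemical assay for solubility (on this read-out lower numbers stand for lower solubility and higher numbers for higher solubility), the measured compounds so far:

Compound 1 `CCOc1ccc2c(c1)C(c1cn[nH]c1)=CN(C)C(=O)[C@@H]2C`: >= 115 ug/mL, a limit
Compound 2 `CCOc1ccc2c(c1)C(c1c[nH]cn1)=CN(C)C(=O)[C@@H]2C`: >= 131 ug/mL, a limit

Compound 2 stands only at a limit, >= 131 ug/mL, and not at a number. Compound 3 `CCOc1ccc2c(c1)C(c1cn(C)cn1)=CN(C)C(=O)[C@@H]2C` carries methyl in place of hydrogen on an aromatic nitrogen, turning 1H-imidazol-4-yl into 1-methyl-1H-imidazol-4-yl: methyl in place of hydrogen on an aromatic nitrogen. Among the measured compounds shown here, the one measured step is a step that the two limits leave unreadable from compound 1 to compound 2, and it concerns a different change, so it offers no size to carry over. No step beyond the scatter is therefore expected in this assay. The expected step is an at least 1.0-fold lower number from compound 2 to compound 3 (0.02 log units; that floor lies within the scatter). For compound 3 the estimated value is 125 ug/mL, with an expected range of 60 ug/mL to 220 ug/mL.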

Compound 3, solubility: 117 ug/mL
The estimate for compound 3 lay 1.1-fold (0.03 log units) above the measured number; the measured number falls inside the stated range.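

In this assay, among the compounds shown here, methyl in place of hydrogen on an aromatic nitrogen gives an at least 1.1-fold lower number from compound 2 to compound 3 (0.04 log units; that floor lies within the scatter), the first step with a readable size. That step has only a floor because compound 2 stands at a limit: the limit of >= 131 ug/mL in this assay, at which 1 of the 3 values shown sits. The steps from compound 1 to compound 2 and to compound 3 cannot be read. On these data alone, how far the true step from compound 2 to compound 3 lies from that floor stays open. So does the effect of an ethyl group, a longer chain or a chain ending in an amine on this same aromatic nitrogen.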